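Amide-nitrogen substituent exchange: from compound 2 to compound 3

This account rests on a few compounds, and the source may have more. Where it says the series, first, only, none or still open, it means among the compounds named here.

Among the measured compounds shown here, compound 2 `CCCCCCCCCCCC(=O)OC[C@H](CSC[C@@H](N)C(=O)N[C@@H](CC)COCC(=O)O)OC(=O)CCCCCCCCCCC` stands at the highest of the two numbers so far in an assay on HEK293 cells for agonist activity at Toll-like receptor 2 (Homo sapiens) (a lower number here means that less compound is needed, a higher number that more compound is needed for the effect), where compound 2 gives 6500 nM. For the measured compounds named here, its nearest neighbour is compound 1 `CCCCCCCCCCCC(=O)OC[C@H](CSC[C@@H](N)C(=O)NC(C)CCc1ccccc1)OC(=O)CCCCCCCCCCC`, which in this assay gives 160 nM; the one measured step, a 41-fold higher number from compound 1 to compound 2 (1.61 log units; beyond the scatter), is the exchange of 1-methyl-3-phenylpropyl for 1-((carboxymethoxy)methyl)propyl on the amide-type nitrogen.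

Compound 3 `CCCCCCCCCCCC(=O)OC[C@H](CSC[C@@H](N)C(=O)NCCCn1ccnc1)OC(=O)CCCCCCCCCCC` is not yet measured. Its difference from compound 2 is 3-(1H-imidazol-1-yl)propyl in place of 1-((carboxymethoxy)methyl)propyl on an amide-type nitrogen. The 1-((carboxymethoxy)methyl)propyl group that entered with the large rise in a 41-fold higher number from compound 1 to compound 2 (1.61 log units; beyond the scatter) leaves again, and a 3-(1H-imidazol-1-yl)propyl group with one five-membered aromatic ring takes its place on the amide-type nitrogen. Going by the values given here, no measured step covers this group directly; the only bearing step is the rise from compound 1 to compound 2, which points towards a lower number once that group is gone.

For compound 3 a downward step of about an 11-fold lower number from compound 2 to compound 3 (1.03 log units; beyond the scatter) is therefore expected in this assay. The estimate for compound 3 is 600 nM, with a range from 120 nM to 3000 nM.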

Compound 3, half-maximal effective concentration: 410 nM
Estimate against measurement, compound 3: 1.5-fold (0.17 log units) above; low and high end bracket the measured number.
By their numbers in this assay, from the lowest: compound 1; then compound 3; then compound 2.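

In this assay, the exchange on the amide-type nitrogen gives a 16-fold lower number from compound 2 to compound 3 (1.20 log units; beyond the scatter) without the phenyl ring of 1-methyl-3-phenylpropyl coming back, so a number well under that of compound 2 does not depend on that ring at this position. The remaining gap, a 2.6-fold higher number from compound 1 to compound 3 (0.41 log units; beyond the scatter), is modest but beyond the scatter: 3-(1H-imidazol-1-yl)propyl recovers much, though not all, of the rise that came with 1-((carboxymethoxy)methyl)propyl. Nothing measured in this series bears on why either step occurs.

Going by these compounds, each exchange changes several features at once, so it remains open whether the high number of compound 2 goes with the carboxylic acid itself or with the rest of 1-((carboxymethoxy)methyl)propyl, a question that a methyl ester or a primary amine on the same chain would address. Also open, on these data alone, is whether the imidazole ring contributes anything of its own, or whether the remaining gap to compound 1 would close with a plain 3-phenylpropyl group or with a methyl branch added to the propyl chain of compound 3.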